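Aryl Amide Variation in an Antiproliferative Series

The source may hold more compounds than are shown below. What is called first, only, known or untested is meant among the compounds shown, and "the series" means these compounds.

Two compounds sharing one core differ only in the aryl group attached to the amide carbonyl. Compound 1 `O=C(Nc1cccc(-c2oc3cc(-c4ccc(F)cc4)ccc3c(=O)c2O)c1)c1ccccc1F` carries a 2-fluorophenyl there, and in a functional assay on MCF7 cells (Homo sapiens) for antiproliferative activity, read by CCK-8 assay, with a stated time of 72 h (on this read-out lower numbers stand for stronger inhibition and higher numbers for weaker inhibition), compound 1 gives 7570 nM. Compound 2 `Cc1cc(C)cc(C(=O)Nc2cccc(-c3oc4cc(-c5ccc(F)cc5)ccc4c(=O)c3O)c2)c1` carries a 3,5-dimethylphenyl instead, and in this assay compound 2 gives 20400 nM, the higher of the two numbers; the step of a 2.7-fold higher number from compound 1 to compound 2 (0.43 log units; beyond the scatter) lies beyond the scatter, so compound 2 is the weaker inhibitor of the pair. Compound 3 `O=C(Nc1cccc(-c2oc3cc(-c4ccc(F)cc4)ccc3c(=O)c2O)c1)c1ccc([N+](=O)[O-])cc1` is the next variation at the same position: 4-nitrophenyl in place of 3,5-dimethylphenyl on a carbonyl carbon. Within the data shown here, only one measured step bears on this change, the exchange of one aryl group for another on the carbonyl carbon, and it was modest. Among the measured compounds shown here, no measured compound carries a 4-nitrophenyl, so the direction of the change is uncertain. Compound 3 is therefore expected to sit between the two measured values, with an estimated step of a 1.9-fold lower number from compound 2 to compound 3 (0.27 log units; within the scatter) in this assay. For compound 3 the estimated value in this assay is 11000 nM, with a range from 3500 nM to 35000 nM.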

Compound 3, half-maximal inhibitory concentration: 3970 nM
Compound 3: middle estimate off by 2.8-fold (0.44 log units), on the high side, within the range that was stated.
By their numbers in this assay, from the lowest: compounds 3 and 1 (each within the scatter of the next); then compound 2.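

Moving from a 3,5-dimethylphenyl to a 4-nitrophenyl on the carbonyl carbon gives a 5.1-fold lower number from compound 2 to compound 3 (0.71 log units; beyond the scatter) in this assay and shows that, with the core held constant, this exchange of one aryl group for another can lower the number as well as raise it. Replacing the 2-fluorophenyl with the 4-nitrophenyl gives a 1.9-fold lower number from compound 1 to compound 3 (0.28 log units; within the scatter) and so does not separate these two aryl groups, which leaves compound 2 as the weakest of the three, its steps to compound 1 and compound 3 both being beyond the scatter. The data give no explanation for why the 3,5-dimethylphenyl stands apart from the other two aryl groups.

These three compounds leave open whether a single methyl on the phenyl ring would already give a number like that of compound 2, and whether an amine or a carboxylic acid in place of the nitro group would read like compound 3. They also leave open whether the position needs an aromatic ring at all, a question that a cyclohexyl on the carbonyl carbon would address.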